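Phenyl for Cyclohexyl on the Amide Nitrogen

The source may report more compounds than this note shows. Statements on the series, on what has been measured and on what is new or still open speak of the compounds shown alone.

The series is assessed in a functional assay on the whole organism (strain CD1) for inhibition, with Mus musculus as the target, with stated times of 15 min and 20 min, at a dose of 10 mg/kg by the subcutaneous route; a lower number here means less inhibition, a higher number more inhibition at the dose given (going by the name of the read-out). Compound 1 `NC/C(=C\c1ccccc1)C(=O)O` gives -2.4%. Compound 2 `CCNC(=O)/C(C#N)=C/c1ccoc1` gives 31%. Compound 3 `N#C/C(=C\c1ccoc1)C(=O)NC1CCCCC1` gives 0%.

Compound 3 stands between the other two on these numbers. Its reading is within the usual scatter of the reading of compound 1, so the two cannot be told apart here, while compound 2 sits clearly higher. Among the measured compounds shown here, the one measured step runs into compound 3: a number 31 percentage points lower from compound 2 to compound 3 (beyond the scatter), with cyclohexyl in place of ethyl on an amide-type nitrogen.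

Compound 4 `N#C/C(=C\c1ccoc1)C(=O)Nc1ccccc1` carries the next change at the same position: phenyl in place of cyclohexyl on an amide-type nitrogen. For the measured compounds named here, no measured pair shows phenyl against cyclohexyl, so the only guide is the step from compound 2 to compound 3, which shows how strongly this assay can respond to what sits on the amide-type nitrogen. A phenyl group has not been tested at this position, so a modest upward step is estimated for compound 4, as a number 10 percentage points higher from compound 3 to compound 4 (within the scatter), with wide uncertainty. Compound 4 is therefore estimated at 10%, within a range from -10% to 35%.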

Compound 4, a percentage reported as inhibition, in the whole organism at one dose (the size of the read-out at that dose, not a potency): 48%
Compound 4: middle estimate off by 38 percentage points, on the low side; measured number above the stated range.
By their numbers in this assay, from the lowest: compounds 1 and 3 (each within the scatter of the next); then compound 2; then compound 4.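

In this assay the outcome at the amide-type nitrogen does not follow the count of atoms in the group, for the result is a number 48 percentage points higher from compound 3 to compound 4 (beyond the scatter) on passing from cyclohexyl to phenyl, two groups of 6 heavy atoms that differ in that the phenyl ring is aromatic and the cyclohexyl ring is not. The earlier step from ethyl to cyclohexyl could have been read as a six-membered ring on this nitrogen going with a low number, but compound 4 goes against that reading, and the comparison with the ethyl amide gives a number 17 percentage points higher from compound 2 to compound 4 (beyond the scatter) and so places phenyl above ethyl at this nitrogen. Nothing available bears on why the aromatic ring and the saturated ring part so widely here.

The compounds shown leave open how a benzyl group or a phenyl ring carrying a methoxy group or a chlorine would read on this nitrogen. They also leave open whether the phenyl amide keeps its reading when the nitrile gives way to a carboxylic acid.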